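The source may report more compounds than this note shows. Statements on the series, on what has been measured and on what is new or still open speak of the compounds shown alone.

Measured compounds in an assay on microsomes from brain for inhibition of Fatty-acid amide hydrolase 1 (Rattus norvegicus), read by fluorescence and HPLC, with a stated time of 60 min; on this read-out lower numbers stand for stronger inhibition and higher numbers for weaker inhibition:
- compound 1, `CCCCCCCCc1ccc(OCC(=O)Cn2nnc(-c3ccc(C(=O)OC)cc3)n2)cc1`: 29 nM
- compound 2, `CCCCCCCCc1ccc(OCC(=O)Cn2nnc(-c3cccc(C(=O)O)c3)n2)cc1`: 36 nM
- compound 3, `CCCCCCCCc1ccc(OCC(=O)Cn2nnnc2C)cc1`: 41 nM

Compound 3 has the highest of the three numbers, but its gaps to compound 2 and to compound 1 both lie within the scatter, so the three compounds are not distinguished by this assay.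

The step under consideration runs from compound 3 to compound 4, `CCCCCCCCc1ccc(OCC(=O)Cn2nnnc2C(=O)OC)cc1`. The change is methoxycarbonyl in place of methyl on an aromatic carbon. Of the measured steps, only a 1.2-fold higher number from compound 1 to compound 2 (0.09 log units; within the scatter) touches a related theme, an ester against an acid on the group carried by the shared core, and that step lay within the scatter. Within the data shown here, no measured pair exchanges a methyl for a methoxycarbonyl on the five-membered ring, so the bearing of the recorded step on this one is indirect.

The account therefore expects no step beyond the scatter, the estimated step being a 1.1-fold higher number from compound 3 to compound 4 (0.04 log units; within the scatter). For compound 4 the estimate in this assay is 45 nM, with a range from 15 nM to 150 nM.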

Compound 4, half-maximal inhibitory concentration: 1000 nM
Estimate against measurement, compound 4: 22-fold (1.35 log units) below, outside the stated range (above it).
By their numbers in this assay, from the lowest: compounds 1, 2 and 3 (each within the scatter of the next); then compound 4.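

In this assay, methoxycarbonyl in place of methyl on the aromatic carbon of the five-membered ring with 4 nitrogen gives a 24-fold higher number from compound 3 to compound 4 (1.39 log units; beyond the scatter). This is the first step among the compounds shown that lies beyond the scatter, so the group on this ring carbon can shift the number strongly, which the earlier compounds, all within the scatter of one another, did not reveal. Nothing in the available data accounts for the size of this step.

The compounds shown leave open how a carboxylic acid, a primary amide or an ethyl group on this same ring carbon would read. Such groups would help to tell whether the step follows the carbonyl, the ester as a whole, or simply a group larger than methyl.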